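Hydroxymethyl on the shared core of compound 2

The source may hold more compounds than are shown below. What is called first, only, known or untested is meant among the compounds shown, and "the series" means these compounds.

Measured in an ADME assay on HEK-293T cells (Homo sapiens) for cytotoxicity, read by luminescence, with a stated time of 24 h (a lower number here means that less compound is tolerated, a higher number that more compound is tolerated), so far:
- compound 1 `CCOC(=O)C1CCN(C(=O)c2cc3sccc3n2Cc2ccc(OC)cc2)CC1` gives 39000 nM 
- compound 2 `CCCNC(=O)C1CCN(C(=O)c2cc3sccc3n2Cc2ccc(OC)cc2)CC1` gives 18800 nM 
- compound 3 `COc1ccc(Cn2c(C(=O)N3CCC(C(=O)NCC4CC4)CC3)cc3sccc32)cc1` gives 24600 nM 

Two steps place compound 2: a 2.1-fold lower number from compound 1 to compound 2 (0.32 log units; beyond the scatter) and a 1.3-fold higher number from compound 2 to compound 3 (0.12 log units; within the scatter) so it sits clear of one neighbour only. Compound 4 `CCCNC(=O)C1CCN(C(=O)c2cc3sc(CO)cc3n2Cc2ccc(OC)cc2)CC1` is compound 2 with hydroxymethyl in place of hydrogen on an aromatic carbon next to the ring sulfur hydroxymethyl in place of hydrogen on an aromatic carbon on the shared core. Among the measured compounds shown here, no measured step touches that place. All three change the group on the carbonyl carbon, and the remaining one a 1.6-fold lower number from compound 1 to compound 3 (0.20 log units; within the scatter) is also small. As far as these compounds go, they give only the general size of change, so no step beyond the scatter is expected in this assay and the direction stays open. The estimate amounts to a 1.2-fold higher number from compound 2 to compound 4 (0.07 log units; within the scatter) as an expected step. The estimated value for compound 4 is 22000 nM with 10000 nM to 50000 nM as its expected range.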

Compound 4, half-maximal cytotoxic concentration: 15500 nM
Compound 4: middle estimate off by 1.4-fold (0.15 log units), on the high side; measured number inside the range.
By their numbers in this assay, from the lowest: compounds 4, 2, 3 and 1 (each within the scatter of the next, the first and the last beyond it).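

In this assay, among the compounds shown here, the aromatic carbon next to the ring sulfur takes hydroxymethyl in place of hydrogen with a 1.2-fold lower number from compound 2 to compound 4 (0.08 log units; within the scatter) and gives the first reading at this place on the shared core, since the earlier steps all changed the group on the carbonyl carbon. At this place, the change does not separate compound 4 from compound 2 in this assay and so adds no measurable shift. Nothing at hand bears on the cause of this result.

Still open, as far as these compounds go, is whether an amine, a carboxylic acid or a longer chain on this carbon would also stay within the scatter of compound 2.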